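Swapping the methylpiperazine of compound 3 for chloro

The source may report more compounds than this note shows. Statements on the series, on what has been measured and on what is new or still open speak of the compounds shown alone.

Measured compounds:
compound 1 `CNC(=O)c1cc(Oc2ccc3nc(NC(=O)c4ccc(Cl)cc4Cl)sc3c2)ccn1` with 14%
compound 2 `CNC(=O)c1cc(Oc2ccc3nc(NC(=O)c4ccc(Cl)cc4)sc3c2)ccn1` with 18.9%
compound 3 `CNC(=O)c1cc(Oc2ccc3nc(NC(=O)Nc4ccc(N5CCN(C)CC5)cc4)sc3c2)ccn1` with 30.5%

In a functional assay on SK-BR-3 cells (Homo sapiens) for inhibition, read by MTT assay, with a stated time of 2 days, tested at 10 uM (a higher number here means more inhibition of growth at the concentration tested, a lower number less inhibition of growth), compound 3 gives 30.5%, the highest of the three numbers. Its nearest neighbour is compound 2 with 18.9%, a gap beyond the scatter, and the furthest is compound 1 with 14%, also beyond the scatter. Among the compounds with values here, the only single-point step among the measured compounds is a number 4.9 percentage points higher from compound 1 to compound 2 (within the scatter), which tells nothing about a change of the kind considered here.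

Compound 4 `CNC(=O)c1cc(Oc2ccc3nc(NC(=O)Nc4ccc(Cl)cc4)sc3c2)ccn1` arises from compound 3 by chloro in place of 4-methylpiperazin-1-yl on an aromatic carbon. Within the data shown here, no measured pair makes exactly this change. Among the measured compounds shown here, compound 2 carries the same chloro, though on a differently built core, and sits well under compound 3; compound 3 is the only compound carrying the methylpiperazine. With nothing to anchor the step, the expectation for compound 4 is a number somewhat under that of compound 3, near the region of compound 2, though with wide uncertainty: the step of a number 10.5 percentage points lower from compound 3 to compound 4 (beyond the scatter) is estimated, downward, of a size beyond the scatter. Compound 4 is therefore expected to give 20%, within 8% to 36%.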

Compound 4, percent growth inhibition at one concentration: 50.8%
Beside the measured number, compound 4's estimate is 30.8 percentage points below it, outside the stated range (above it).
By their numbers in this assay, from the lowest: compounds 1 and 2 (each within the scatter of the next); then compound 3; then compound 4.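

In this assay, the aromatic carbon para to a large group turns out not to need the 4-methylpiperazin-1-yl: with chloro in its place, the result is a number 20.3 percentage points higher from compound 3 to compound 4 (beyond the scatter), a modest step, so the larger ring-bearing group is not required for growth inhibition at this concentration. Within the data shown here, compound 4 also shows what the earlier compounds could not, that the group on the carbonyl carbon matters more than the one chloro-for-hydrogen step had suggested: (4-chlorophenyl)amino in place of 4-chlorophenyl gives a number 31.9 percentage points higher from compound 2 to compound 4 (beyond the scatter), and (4-chlorophenyl)amino in place of 2,4-dichlorophenyl gives a number 36.8 percentage points higher from compound 1 to compound 4 (beyond the scatter), both large steps. No measurement at hand explains any of these rises.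

The compounds shown leave open whether chloro itself matters at this place or whether a plain hydrogen, a methoxy group or a small amine such as dimethylamino would serve as well. They also leave open whether the 4-methylpiperazin-1-yl group would behave the same way on a ring joined to the carbonyl carbon without the amino link.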